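A Pyridin-2-yl Variant of Compound 3

The compounds below may be only part of what the source reports. "The series", "measured", "known", "first", "only" and "open" are said of these compounds alone.

Three compounds share one core and differ only in the group carried on an amine nitrogen in a ring. In a functional assay on HCT-116 cells (Homo sapiens) for antiproliferative activity, read by MTT assay, with a stated time of 72 h (on this read-out lower numbers stand for stronger inhibition and higher numbers for weaker inhibition), compound 1 `Cc1ccc(N2CCN(C(=S)SCc3ccc4nc(N)nc(N)c4c3)CC2)cc1` gives 5510 nM, compound 2 `Cc1ccc(N2CCN(C(=S)SCc3ccc4nc(N)nc(N)c4c3)CC2)c(C)c1` gives 4070 nM, and compound 3 `Nc1nc(N)c2cc(CSC(=S)N3CCN(c4ccc(F)cc4)CC3)ccc2n1` gives 3270 nM. Compound 3 has the lowest number of the three, yet the steps of a 1.7-fold lower number from compound 1 to compound 3 (0.23 log units; within the scatter) and a 1.2-fold lower number from compound 2 to compound 3 (0.10 log units; within the scatter) both lie within the scatter, as does a 1.4-fold lower number from compound 1 to compound 2 (0.13 log units; within the scatter). Within the data shown here, compound 4 `Nc1nc(N)c2cc(CSC(=S)N3CCN(c4ccccn4)CC3)ccc2n1` is reached from compound 3 by a single change. pyridin-2-yl in place of 4-fluorophenyl on an amine nitrogen in a ring None of the measured steps exchanges the aromatic ring itself; all three vary its substituents, and none moved the read-out beyond the scatter. The expected step for compound 4 is therefore a 1.1-fold higher number from compound 3 to compound 4 (0.03 log units; within the scatter), meaning none beyond the scatter. Compound 4 is estimated at 3500 nM, with a range from 1500 nM to 8500 nM.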

Compound 4, half-maximal inhibitory concentration: 5960 nM
Compound 4: the middle estimate sits 1.7-fold (0.23 log units) below what was measured; low and high end bracket the measured number.
By their numbers in this assay, from the lowest: compounds 3, 2, 1 and 4 (each within the scatter of the next).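

In this assay, putting an aromatic ring with a hetero atom in place of a carbon-only one on this amine nitrogen gives a 1.8-fold higher number from compound 3 to compound 4 (0.26 log units; within the scatter) and a 1.5-fold higher number from compound 2 to compound 4 (0.17 log units; within the scatter) and a 1.1-fold higher number from compound 1 to compound 4 (0.03 log units; within the scatter) as its three steps. This exchange of the ring itself, which adds a hydrogen-bond acceptor, therefore stays within the scatter, just as the substituent changes did, and the four compounds remain unseparated. No measurement shown offers any explanation for these steps. Still open, from the compounds shown here alone, is whether an amine or a carboxylic acid on this aromatic ring would move the read-out beyond the scatter.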